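Two Triazole Cores, One Substituent Swap, and an Assay Floor

A few compounds are considered here, and "the series" means these few. Any claim that something is new, unique, unknown or untested is made for them only; others in the source may bear on it.

The study examines four compounds built on two related triazole-bearing cores, each carrying a trimethoxyphenyl group, and tests them in a functional assay on A549 cells (Homo sapiens) for antiproliferative activity, read by MTT assay, with a stated time of 72 h; a higher number here means a weaker inhibitor, a lower number a stronger inhibitor. Compound 1 `COc1cc(-c2ncnn2-c2ccc([N+](=O)[O-])cc2)cc(OC)c1OC` and compound 2 `COc1cc(-c2ncnn2-c2ccc(Cl)cc2)cc(OC)c1OC` share one core; compound 3 `COc1cc(-n2ncnc2-c2cccc([N+](=O)[O-])c2)cc(OC)c1OC` and compound 4 `COc1cc(-n2ncnc2-c2cccc(Cl)c2)cc(OC)c1OC` share another. The difference between the two cores is not broken down here; compound 3 and compound 1 are built from the same atoms joined differently.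

In this assay compound 1 reaches only the limit of > 10000 nM, which is a limit and not a number. Compound 2 likewise reaches only the limit of > 10000 nM. Compound 3 also reaches only the limit of > 10000 nM. The change from compound 1 to compound 2 is chloro in place of nitro on an aromatic carbon, and the step it made, a step that the two limits leave unreadable from compound 1 to compound 2, cannot be sized, since (the limit of > 10000 nM in this assay, at which 3 of the 3 values shown sit).

Compound 4 is not yet measured. The change from compound 3 to compound 4 is chloro in place of nitro on an aromatic carbon; it is the same kind of change as that from compound 1 to compound 2, though the place differs, para to a large group in the earlier pair and meta to a large group here. Because (the limit of > 10000 nM in this assay, at which 3 of the 3 values shown sit), the step from compound 3 to compound 4 is expected to be a step that the limit leaves unreadable from compound 3 to compound 4 and most probably to end again at a limit. Compound 4 is therefore expected to give about 15000 nM in this assay, with a plausible range from 5000 nM to 50000 nM.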

Compound 4, half-maximal inhibitory concentration: > 10000 nM
Compound 4: a limit, no number (the forecaster's own chance of this, stated with the estimate: 85%); the middle value does not contradict the limit.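

In this assay, no size can be given for the change from compound 3 to compound 4, chloro in place of nitro, because neither compound yields a number: the limit of > 10000 nM in this assay, at which 4 of the 4 values shown sit. The compounds shown leave open what any of the four would read as an actual number in this assay, and so whether that change or the difference between the two cores matters at all.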